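The source may hold more compounds than are shown below. What is called first, only, known or untested is meant among the compounds shown, and "the series" means these compounds.

Working notes on the series. Compound 1 `Cc1csc2cc([C@H](C)Nc3ncnc(N)c3C#N)c(-c3cccc(CN4CCC(CN(C)Cc5ccccn5)CC4)c3)c(=O)n12` is the reference here. Among the compounds with values here, in a physicochemical assay for acid dissociation, compound 1 gives 9, the higher of the two numbers measured so far. Compound 2 `Cc1csc2cc([C@H](C)Nc3ncnc(N)c3C#N)c(-c3cccc(CN(C)CCCN(C)Cc4ccc(Cl)cc4)c3)c(=O)n12` gives 8.8 in this assay, a value that sits within the scatter of the number for compound 1, so the two are not told apart.

Compound 3 `Cc1csc2cc([C@H](C)Nc3ncnc(N)c3C#N)c(-c3cccc(CN4CCC(N(C)CCC(F)(F)F)CC4)c3)c(=O)n12` has not been measured. It differs from compound 1 in one place: methyl(3,3,3-trifluoropropyl)amino in place of (methyl((pyridin-2-yl)methyl)amino)methyl on a saturated ring carbon. Within the data shown here, no step between measured compounds bears on this exchange, so there is nothing in the numbers to anchor its size. On the two values shown, which lie within the scatter of each other, the step expected from this change is a number 0.20 log units lower from compound 1 to compound 3 (within the scatter), that is, no movement beyond the scatter. Compound 3 is therefore expected to give about 8.8 in this assay, with a range from 8.2 to 9.4.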

Compound 3, acid dissociation constant: 7.3
The estimate for compound 3 lay 1.50 log units above the measured number; measured number below the stated range.
By their numbers in this assay, from the lowest: compound 3; then compounds 2 and 1 (each within the scatter of the next).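

In this assay, placing methyl(3,3,3-trifluoropropyl)amino on the saturated ring carbon, three ring bonds from the ring nitrogen, gives a number 1.70 log units lower from compound 1 to compound 3 (beyond the scatter) and so shows that the number is sensitive to the group at this position. The exchange removes a six-membered aromatic ring with 1 hetero atom and introduces 3 fluorine atoms while also changing the heavy-atom count, so this one step cannot assign the movement to any single part of the change. No measurement shown offers an explanation for the size of this step.

On these data alone, it remains open whether methyl(propyl)amino, which has no fluorine, would give a number nearer that of compound 1 or that of compound 3. As far as these compounds go, it also remains open whether a longer chain carrying the same trifluoromethyl end, or dimethylamino at this position, would give a higher or a lower read-out than compound 3.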